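Losing the Terminal Amine: What Happens to Compound 3?

The source may hold more compounds than are shown below. What is called first, only, known or untested is meant among the compounds shown, and "the series" means these compounds.

Measured in a functional assay on HepG2 cells (Homo sapiens), read by MTT assay, with a stated time of 48 h; a higher number here means a weaker inhibitor, a lower number a stronger inhibitor:
- compound 1 `CCN(CC)CCNC(=O)c1ccc(C(CC)(CC)c2ccc(OCC(O)C(C)(C)C)c(C)c2)n1CC`: 490 nM
- compound 2 `CCn1c(C(=O)NCC(OC)OC)ccc1C(CC)(CC)c1ccc(OCC(O)C(C)(C)C)c(C)c1`: 23200 nM
- compound 3 `CCn1c(C(=O)NCCN)ccc1C(CC)(CC)c1ccc(OCC(O)C(C)(C)C)c(C)c1`: 176 nM

Compound 3 has the lowest number of the three, making it the strongest inhibitor so far. Compound 4 `CCn1c(C(=O)N(C)CCC#N)ccc1C(CC)(CC)c1ccc(OCC(O)C(C)(C)C)c(C)c1` places (2-cyanoethyl)(methyl)amino in place of (2-aminoethyl)amino on a carbonyl carbon. Like compound 2, compound 4 lacks the amino or diethylamino group of the other two. Two large steps bear on this: a 130-fold lower number from compound 2 to compound 3 (2.12 log units; beyond the scatter) and a 47-fold higher number from compound 1 to compound 2 (1.68 log units; beyond the scatter). Swapping diethylamino for amino gave only a modest step, a 2.8-fold lower number from compound 1 to compound 3 (0.44 log units; beyond the scatter). A large rise in this assay is therefore expected. Going by the values given here, no measured compound carries the new group, so the range is wide. The expected change is a 51-fold higher number from compound 3 to compound 4 (1.71 log units; beyond the scatter). For compound 4 the estimated value is 9000 nM, with an expected range of 2000 nM to 35000 nM.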

Compound 4, half-maximal inhibitory concentration: > 50000 nM
Compound 4: a limit, no number; the forecaster's own chance of this, stated with the estimate: 10%; middle value at least 5.5-fold (0.74 log units) from the limit.
By their numbers in this assay, from the lowest: compound 3; then compound 1; then compound 2. At a limit, above all of these: compound 4.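

Compound 4 gives a limit, not a number: the limit of > 50000 nM in this assay, at which 1 of the 4 values shown sits. Its (2-cyanoethyl)(methyl)amino group on the carbonyl carbon still yields clear steps against both compounds with a terminal amine: an at least 280-fold higher number from compound 3 to compound 4 (2.45 log units; beyond the scatter) and an at least 100-fold higher number from compound 1 to compound 4 (2.00 log units; beyond the scatter). Compound 2 also lacks that amine, yet there is an at least 2.1-fold higher number from compound 2 to compound 4 (0.33 log units; beyond the scatter), so the level of compound 2 is not the ceiling for chains without it.

The new group brings in a nitrile and a methyl together, and the compounds shown leave their separate contributions open. A (2-cyanoethyl)amino group and a (2-aminoethyl)(methyl)amino group would each carry only one of the two.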